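Removing one bromine from a bis-indolyl imidazole

The source may report more compounds than this note shows. Statements on the series, on what has been measured and on what is new or still open speak of the compounds shown alone.

Measured compounds:
compound 1 `Brc1ccc2c(-c3c[nH]c(-c4c[nH]c5cc(Br)ccc45)n3)c[nH]c2c1` gives 2140 nM in an assay on CHO cells for binding affinity to Alpha-1A adrenergic receptor (Homo sapiens); on this read-out higher numbers stand for weaker inhibition and lower numbers for stronger inhibition;
compound 2 `Brc1ccc2c(-c3nc(-c4c[nH]c5ccccc45)c[nH]3)c[nH]c2c1` gives 770 nM.

Going by the values given here, compound 1 stands at the higher of the two numbers so far: compound 2 lies below it by a 2.8-fold lower number from compound 1 to compound 2 (0.44 log units; beyond the scatter), a difference beyond the usual scatter. Compound 3 `Brc1ccc2c(-c3c[nH]c(-c4c[nH]c5ccccc45)n3)c[nH]c2c1` is not yet measured. It differs from compound 1 in one place: hydrogen in place of bromo on an aromatic carbon. Among the compounds with values here, this is a change of the same kind as the one between compound 1 and compound 2, which also traded a bromo for hydrogen on an aromatic carbon, only at the other of the two bromo-bearing positions of the shared core. Within the data shown here, since that single comparison is the only guide, compound 3 is expected to move the same way, by about a 2.7-fold lower number from compound 1 to compound 3 (0.43 log units; beyond the scatter). The estimate for compound 3 is therefore 800 nM, with a likely range from 350 nM to 1800 nM.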

Compound 3, inhibition constant: 550 nM
Compound 3: the middle estimate sits 1.5-fold (0.16 log units) above what was measured; measured number inside the range.
By their numbers in this assay, from the lowest: compounds 3 and 2 (each within the scatter of the next); then compound 1.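

In this assay the bromo on this aromatic carbon can also give way to hydrogen with a lower number, a 3.9-fold lower number from compound 1 to compound 3 (0.59 log units; beyond the scatter). Together with a 2.8-fold lower number from compound 1 to compound 2 (0.44 log units; beyond the scatter), this shows that compound 1 gains from losing either one of its two bromo groups, so the effect is not confined to a single place on the shared core. No measurement on hand explains why the number falls with this change.

The compounds shown leave open whether hydrogen at both places would lower the number further, since each compound here still carries one bromo. They also leave open how other groups on this same carbon, such as a methoxy group, an amine or a carboxylic acid, would compare with bromo and hydrogen.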